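A few compounds are considered here, and "the series" means these few. Any claim that something is new, unique, unknown or untested is made for them only; others in the source may bear on it.

In a functional assay on HepG2 cells (Homo sapiens) for cytotoxicity, read by MTT assay, with a stated time of 48 h (on this read-out lower numbers stand for stronger inhibition and higher numbers for weaker inhibition), compound 1 (`COc1cc(/C=C/C(=O)/C=C/c2nc3ccccc3n2C)ccc1O`) gives 2900 nM and compound 2 (`COc1cc(/C=C/C(=O)/C=C/c2nc3cc(Cl)ccc3n2C)ccc1O`) gives 4000 nM as its value, two numbers within the usual scatter of each other. Compound 3 (`COc1cc(/C=C/C(=O)/C=C/c2nc3cc([N+](=O)[O-])ccc3n2C)ccc1O`) awaits measurement, and its difference from compound 1 (nitro in place of hydrogen on an aromatic carbon) is nitro in place of hydrogen on an aromatic carbon. Among the measured compounds shown here, the only measured step that bears on it, chloro in place of hydrogen on an aromatic carbon, stays within the scatter (a 1.4-fold higher number from compound 1 to compound 2 (0.14 log units; within the scatter)), so no step beyond the scatter is expected in this assay and no direction can be favoured. The expected step is small (a 1.2-fold higher number from compound 1 to compound 3 (0.08 log units; within the scatter)). For compound 3 the estimated value is 3500 nM with 1300 nM to 9000 nM as the expected range.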

Compound 3, half-maximal inhibitory concentration: 3700 nM
Compound 3: the middle estimate sits 1.1-fold (0.02 log units) below what was measured; low and high end bracket the measured number.
By their numbers in this assay, from the lowest: compounds 1, 3 and 2 (each within the scatter of the next).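

In this assay, nitro in place of hydrogen on this aromatic carbon stays within the scatter (a 1.3-fold higher number from compound 1 to compound 3 (0.11 log units; within the scatter)), and so does nitro in place of chloro (a 1.1-fold lower number from compound 2 to compound 3 (0.03 log units; within the scatter)). A second substituent, with a different set of atoms from chloro, therefore leaves the number at this position indistinguishable from that with hydrogen. No measurement offered here accounts for this result. The compounds shown leave open whether an amine or a carboxylic acid on this carbon would give a step beyond the scatter. They also leave open whether any other position responds more strongly.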